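Whole-animal response series: step from compound 1 to compound 4

The source may hold more compounds than are shown below. What is called first, only, known or untested is meant among the compounds shown, and "the series" means these compounds.

Measured compounds:
compound 1, `Nc1nc(O)c2c(n1)n(C1OC(CO)[C@@H](O)[C@H]1O)c(=O)n2C/C=C/c1ccccc1`: 5%
compound 2, `CCCn1c(=O)n(C2CCC(COC(C)=O)O2)c2nc(NC(C)=O)nc(O)c21`: 11%
compound 3, `C=CCn1c(=O)n([C@@H]2O[C@H](CO)[C@H]3OC(C)(CCC(=O)NC)O[C@H]32)c2nc(N)nc(O)c21`: 0%

All three numbers come from a functional assay on the whole organism with Mus musculus as the target; on this read-out lower numbers stand for smaller maximal responses and higher numbers for larger maximal responses. In this assay compound 1 gives 5%, compound 2 gives 11% and compound 3 gives 0%. The three values lie close together: compound 1 differs from compound 3 and from compound 2 by less than the usual scatter of the read-out, so no order among the three can be read from these numbers, and none of them is to be called the strongest or the weakest. Among the measured compounds shown here, the series so far shows only small maximal responses with no step that stands out.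

Compound 4, `NC(=O)Cn1c(=O)n(C2OC(CO)[C@@H](O)[C@H]2O)c2nc(N)nc(O)c21`, has not been measured. It differs from compound 1 by carbamoyl in place of 2-phenylethenyl on a saturated chain carbon bound to an aromatic nitrogen. For the measured compounds named here, no pair of measured compounds shows this change, so the expectation for it rests on the three values alone, which all sit at the low end of the scale within the scatter of one another.

For compound 4 in this assay the step of a number 1 percentage points higher from compound 1 to compound 4 (within the scatter) is expected to stay within the scatter, with no clear direction. The estimate for compound 4 is 6%, with a range from 0% to 20%.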

Compound 4, largest response reached (reported as maximal response), in percent of the reference or control that the assay uses: 72%
Estimate against measurement, compound 4: 66 percentage points below; the measured number lies above the stated range.
By their numbers in this assay, from the lowest: compounds 3, 1 and 2 (each within the scatter of the next, the first and the last beyond it); then compound 4.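

In this assay, carbamoyl in place of 2-phenylethenyl on a saturated chain carbon bound to an aromatic nitrogen gives a number 67 percentage points higher from compound 1 to compound 4 (beyond the scatter), a large step well beyond the scatter. Among the compounds shown here, this shows that the group at this position can separate a small maximal response from a large one on the core of compound 1, which the earlier compounds could not show, as no two of them differ in one place only. No measurement among the data shown accounts for this step.

For the compounds shown here, the single pair leaves open whether the step follows the loss of the six-membered aromatic ring, the smaller group, or the arrival of the hydrogen-bond donor and acceptor, as all of these change together here. A plain ethyl group would test the loss of the ring without the carbamoyl, while a carboxylic acid, a primary amine or a longer chain ending in carbamoyl at the same place would show how closely the response depends on carbamoylmethyl itself.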